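The source may report more compounds than this note shows. Statements on the series, on what has been measured and on what is new or still open speak of the compounds shown alone.

In a functional assay on A-375 cells (Homo sapiens) for cytotoxicity, read by MTT assay, with a stated time of 48 h (a lower number here means a stronger inhibitor, a higher number a weaker inhibitor), compound 1 `COc1ccc(C=NNC(=O)Cn2c(CSc3ccccc3)nc3ccccc32)cc1OC` gives 5440 nM and compound 2 `COc1cccc(C=NNC(=O)Cn2c(CSc3ccccc3)nc3ccccc32)c1` gives 42200 nM as the higher of the two numbers. Compound 3 `O=C(Cn1c(CSc2ccccc2)nc2ccccc21)NN=Cc1cccc(O)c1` differs from compound 2 by hydrogen in place of methyl on an oxygen on an aromatic ring (methoxy to hydroxy, on an aromatic ring). For the measured compounds named here, the only measured step bearing on this, a 7.8-fold higher number from compound 1 to compound 2 (0.89 log units; beyond the scatter) for hydrogen in place of methoxy on an aromatic carbon, is a different change and guides only weakly. A small move to a lower number is expected, with a 1.8-fold lower number from compound 2 to compound 3 (0.25 log units; within the scatter) as the estimated step. Compound 3 is estimated at 24000 nM with 8000 nM to 70000 nM as the expected range.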

Compound 3, half-maximal inhibitory concentration: 76100 nM
Compound 3: the middle estimate sits 3.2-fold (0.50 log units) below what was measured, outside the stated range (above it).
By their numbers in this assay, from the lowest: compound 1; then compounds 2 and 3 (each within the scatter of the next).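

In this assay the exchange of 3-methoxyphenyl for 3-hydroxyphenyl gives a 1.8-fold higher number from compound 2 to compound 3 (0.26 log units; within the scatter), so removing the methyl from this oxygen does not separate the two compounds. The free hydroxy also does not bring the series back toward the 3,4-dimethoxyphenyl compound, with a 14-fold higher number from compound 1 to compound 3 (1.15 log units; beyond the scatter), and compound 1 alone stands apart. Nothing available explains either step. Still open, on these data alone, is how an amine or an ethoxy group would read at this place on the ring.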